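Replacing an acetyl with hydrogen on a terpenoid ester core

A few compounds are considered here, and "the series" means these few. Any claim that something is new, unique, unknown or untested is made for them only; others in the source may bear on it.

compound 1 `C/C=C(\C)C(=O)O[C@H]1C[C@@]2(C)O[C@H]2[C@@H](OC(C)=O)[C@@]2(C)CC[C@@](O)(C(C)C)[C@H]12`: > 100000 nM
compound 2 `COc1ccc(C(=O)O[C@H]2CC(C)=C[C@H](O)[C@@]3(C)[C@@H](OC(C)=O)C[C@@](O)(C(C)C)[C@H]23)cc1`: 34400 nM
compound 3 `COc1ccc(C(=O)O[C@H]2CC(C)=C[C@@H](OC(C)=O)[C@@]3(C)[C@@H](OC(C)=O)C[C@@](O)(C(C)C)[C@H]23)cc1`: 42900 nM

In a functional assay on RS4-11 cells (Homo sapiens) for cytotoxicity, read by MTT assay, with a stated time of 72 h (on this read-out lower numbers stand for stronger inhibition and higher numbers for weaker inhibition), compound 1 gives > 100000 nM, which is a limit of the assay and not a number, as the limit of > 100000 nM in this assay, at which 1 of the 3 values shown sits, shows. Compound 2 gives 34400 nM in this assay, and compound 3 gives 42900 nM; the two numbers lie within the scatter of one another, so compound 3 stands alongside compound 2 among the numbers at hand, both weak. Compound 4 `COc1ccc(C(=O)O[C@H]2CC(C)=C[C@@H](O)[C@@]3(C)[C@@H](OC(C)=O)C[C@@](O)(C(C)C)[C@H]23)cc1` is not yet measured. It differs from compound 3 in one place: hydrogen in place of acetyl on an oxygen on a saturated carbon. Going by the values given here, no step between measured compounds is known here, so the expectation rests on compound 3 with 42900 nM and on compound 2 with 34400 nM. The step of a 1.1-fold lower number from compound 3 to compound 4 (0.03 log units; within the scatter) is expected to stay within the scatter. Compound 4 is estimated at 40000 nM, between 15000 nM and 100000 nM.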

Compound 4, half-maximal inhibitory concentration: 70400 nM
For compound 4 the middle estimate is 1.8-fold (0.25 log units) below the measured one; low and high end bracket the measured number.
By their numbers in this assay, from the lowest: compounds 2, 3 and 4 (each within the scatter of the next, the first and the last beyond it). At a limit, above all of these: compound 1.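

In this assay, going from acetoxy to hydroxy on this oxygen stays within the scatter: a 1.6-fold higher number from compound 3 to compound 4 (0.22 log units; within the scatter). The drawn stereocentre at the saturated ring carbon gives a modest step beyond the scatter: a 2.0-fold higher number from compound 2 to compound 4 (0.31 log units; beyond the scatter). That step can be laid to the stereocentre alone: the fact that compounds 2 and 4 differ only in the configuration as drawn. The compounds shown leave open whether a butyryl group or an amine in place of the acetyl would move the number out of this weak range. They also leave open whether the same stereocentre matters when the oxygen carries an acetyl.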